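This account rests on a few compounds, and the source may have more. Where it says the series, first, only, none or still open, it means among the compounds named here.

In a functional assay on A2780 cells (Homo sapiens) for inhibition (on this read-out higher numbers stand for weaker inhibition and lower numbers for stronger inhibition), compound 2 (`CCNCc1cc(-c2c(C(=O)NCC)noc2-c2cc(C(C)C)c(O)cc2O)on1`) gives 45 nM and compound 3 (`CCNC(=O)c1noc(-c2cc(C(C)C)c(O)cc2O)c1-c1cc(CN2CCCCC2)no1`) gives 62 nM, so compound 3 stands within the usual scatter of compound 2. For compound 1 (`CCNC(=O)c1noc(-c2cc(C(C)C)c(O)cc2O)c1-c1cc(CNC)no1`) the result reads "not determined" (no result reported), so it offers no number to compare.

Compound 4 (`CCNC(=O)c1cc(-c2c(C(=O)NCC)noc2-c2cc(C(C)C)c(O)cc2O)on1`) has ethylcarbamoyl in place of the (piperidin-1-yl)methyl of compound 3, on an aromatic carbon: ethylcarbamoyl in place of (piperidin-1-yl)methyl on an aromatic carbon.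

Among the measured compounds shown here, only one measured step bears on this change. It is a 1.4-fold higher number from compound 2 to compound 3 (0.14 log units; within the scatter), where piperidin-1-yl took the place of ethylamino on a saturated chain carbon. That small step offers no reason to expect a large shift in this assay, so no step beyond the scatter is expected, in either direction. For the measured compounds named here, it is a weak guide, however, as no measured compound carries ethylcarbamoyl at this place, and the range must stay wide.

The expected step is a 1.0-fold lower number from compound 3 to compound 4 (0.01 log units; within the scatter). Compound 4 is estimated at 60 nM, with an expected range from 20 nM to 180 nM.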

Compound 4, half-maximal inhibitory concentration: 43 nM
For compound 4 the middle estimate is 1.4-fold (0.14 log units) above the measured one, and the stated range covers the measured number.
By their numbers in this assay, from the lowest: compounds 4, 2 and 3 (each within the scatter of the next).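

In this assay, the two earlier compounds with a number both carry an amine on a saturated chain carbon at this place, on the five-membered aromatic ring with 1 nitrogen and 1 oxygen. Compound 4 shows that this amine is not needed for a reading in the same range: ethylcarbamoyl, an amide with no ring, stays within the scatter of both neighbours (a 1.4-fold lower number from compound 3 to compound 4 (0.16 log units; within the scatter); a 1.0-fold lower number from compound 2 to compound 4 (0.02 log units; within the scatter)). No measurement here explains this result, so the reason for it remains unknown.

What stands open is how far this tolerance extends. A carboxylic acid at this place, or an amide with a chain longer than ethyl, could either keep the reading in this range or move it clearly beyond the scatter.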